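Swapping fluoro for nitro on a shared core

The compounds below may be only part of what the source reports. "The series", "measured", "known", "first", "only" and "open" are said of these compounds alone.

Of the compounds shown here, three that share one core have been measured in a functional assay on SCC-7 cells (Mus musculus) for inhibition; on this read-out lower numbers stand for stronger inhibition and higher numbers for weaker inhibition. Compound 1 `Nc1n[n+]([O-])c2c(F)cccc2[n+]1[O-]` gives 23700 nM and compound 2 `Nc1n[n+]([O-])c2c(Cl)cccc2[n+]1[O-]` gives 8200 nM in this test. Compound 3 `Nc1n[n+]([O-])c2cc(F)ccc2[n+]1[O-]` gives 17600 nM and so lies within the scatter of compound 1, while the number of compound 2 lies lower, beyond the scatter.

Compound 4 `Nc1n[n+]([O-])c2cc([N+](=O)[O-])ccc2[n+]1[O-]` differs from compound 3 by a single change: nitro in place of fluoro on an aromatic carbon. This puts nitro in place of fluoro on an aromatic carbon. Going by the values given here, no nitro compound has been measured yet, so the evidence is thin. Among the compounds with values here, the only measured step that replaces fluoro is a 2.9-fold lower number from compound 1 to compound 2 (0.46 log units; beyond the scatter), where chloro enters. It is a modest step, and it involves another group at another place, which makes it a loose guide.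

A step of similar size and direction seems the best guess. The expected change in this assay is a 2.9-fold lower number from compound 3 to compound 4 (0.47 log units; beyond the scatter), though with wide uncertainty. Compound 4 is therefore expected to give about 6000 nM (estimated range 1500 nM to 20000 nM).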

Compound 4, half-maximal inhibitory concentration: 2800 nM
The estimate for compound 4 lay 2.1-fold (0.33 log units) above the measured number, and the stated range covers the measured number.
By their numbers in this assay, from the lowest: compound 4; then compound 2; then compounds 3 and 1 (each within the scatter of the next).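

In this assay, this aromatic carbon does not merely accept fluoro: replacing it with nitro gives a 6.3-fold lower number from compound 3 to compound 4 (0.80 log units; beyond the scatter), so what sits at this position can move the number well beyond the scatter. Going by these compounds alone, this is the first view of any group other than fluoro at this carbon, and the first view of a nitro group on the shared core. Set beside a 2.9-fold lower number from compound 1 to compound 2 (0.46 log units; beyond the scatter), which comes from a change at another place, it gives a second case in which replacing fluoro lowers the number, this time with a larger group of three heavy atoms.

From the compounds shown here alone, whether an amine or a carboxylic acid on the same carbon would shift the number too, and whether nitro would give a similar step at the carbon bearing fluoro in compound 1, remains open. Nothing shown here gives a reason for the drop.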